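The compounds below may be only part of what the source reports. "The series", "measured", "known", "first", "only" and "open" are said of these compounds alone.

Compound 1 `Cn1c(Cc2nn(C)c(=O)c3ccccc23)nnc1SCC(=O)Nc1ccc(Cl)cc1Cl` is the weaker of the two compounds measured: in an assay on 32D cells for inhibition of interleukin-15 (Mus musculus), read by resazurin assay, with stated times of 30 min and 2.5 days, in the presence of a further agent that is not named here (on this read-out higher numbers stand for weaker inhibition and lower numbers for stronger inhibition), compound 1 gives 21100 nM, whereas compound 2 `Cn1nc(Cc2nnc(SCCCCCCCC(=O)Nc3ccc(Cl)cc3Cl)n2CCC=O)c2ccccc2c1=O` gives 5500 nM, a difference that lies beyond the scatter. The two differ in several places, so no single step can be read from them. Compound 3 `Cn1nc(Cc2nnc(SCC(=O)Nc3ccc(Cl)cc3Cl)n2CCC(=O)O)c2ccccc2c1=O` differs from compound 1 in one place only: carboxymethyl in place of hydrogen on a saturated chain carbon bound to an aromatic nitrogen, so that the methyl on the aromatic nitrogen becomes a 2-carboxyethyl. For the measured compounds named here, no measured pair shows this change. Compound 3 is expected to sit near compound 1, with a step of a 1.4-fold lower number from compound 1 to compound 3 (0.15 log units; within the scatter) that may fall within the scatter. The estimated value for compound 3 is 15000 nM, ranging from 4000 nM to 50000 nM.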

Compound 3, half-maximal inhibitory concentration: > 30000 nM
Compound 3: no number, only a limit; the forecaster's own chance of this, stated with the estimate: 15%; at least 2.0-fold (0.30 log units) between middle value and limit.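

In this assay compound 3 gives > 30000 nM, which is a limit of the assay and not a number. Carboxymethyl in place of hydrogen on a saturated chain carbon bound to an aromatic nitrogen gives an at least 1.4-fold higher number from compound 1 to compound 3 (0.15 log units; that floor lies within the scatter), the first single-place step at this position. It shows no gain in inhibition from the 2-carboxyethyl group here, though the size of any loss cannot be read.

On these data alone, the true value of compound 3 stays open. So does whether an amine or a primary amide at the end of this chain would behave like the carboxylic acid.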